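Guanidine series: swapping pyridin-2-yl for benzyl

A few compounds are considered here, and "the series" means these few. Any claim that something is new, unique, unknown or untested is made for them only; others in the source may bear on it.

Compound 1 `N=C(NCCCc1c[nH]cn1)NCCC(c1ccc(F)cc1)c1ccccn1` is the reference point. In a functional assay on cardiac atrium for agonist activity at histamine H2 receptor (Cavia porcellus) (on this read-out higher numbers stand for larger maximal responses and lower numbers for smaller maximal responses), compound 1 gives 1, level with compound 3 and together the highest of the three numbers measured. Compound 2 `N=C(NCCCc1c[nH]cn1)NCCC(c1ccc(C(F)(F)F)cc1)c1ccccn1` gives 0.9 and compound 3 `N=C(NCCCc1c[nH]cn1)NCCC(c1cccc(C(F)(F)F)c1)c1ccccn1` gives 1. The three measured steps all stay within the scatter: a number 0.10 lower from compound 1 to compound 2 (within the scatter), no change at the digits printed from compound 1 to compound 3 (within the scatter), and a number 0.10 higher from compound 2 to compound 3 (within the scatter).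

Compound 4 `N=C(NCCCc1c[nH]cn1)NCCC(Cc1ccccc1)c1ccc(F)cc1` differs from compound 1 by benzyl in place of pyridin-2-yl on a saturated chain carbon bound to an aromatic carbon and a saturated chain carbon. For the measured compounds named here, none of the measured steps touches this position on the saturated chain carbon bound to an aromatic carbon and a saturated chain carbon; they alter only the other aromatic group, and each of them leaves the maximal response essentially unchanged. Going by the values given here, the data therefore give no direct precedent for the loss of the pyridin-2-yl group, and the expectation rests on the maximal response having stayed high across every change seen so far.

For compound 4 the expected step is a number 0.10 lower from compound 1 to compound 4 (within the scatter), a modest downward drift rather than a clear change. Compound 4 is estimated at 0.9 in this assay, with a range from 0.6 to 1.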

Compound 4, intrinsic activity: the largest response reached, as a fraction of the reference agonist's: 0.8
Beside the measured number, compound 4's estimate is 0.10 above it; the measured number falls inside the stated range.
By their numbers in this assay, from the lowest: compounds 4, 2, 1 and 3 (each within the scatter of the next, the first and the last beyond it).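

Benzyl in place of pyridin-2-yl on the saturated chain carbon gives, in this assay, a number 0.20 lower from compound 1 to compound 4 (beyond the scatter) and is the only step shown to pass beyond the scatter, so this position responds where the changes on the other aromatic group did not. Compound 4 still gives 0.8 as its maximal response, so a substantial response survives without pyridin-2-yl at this position. Nothing at hand accounts for the step.

The change removes a ring nitrogen and adds a carbon at once, so phenyl or pyridin-2-ylmethyl at this position would be needed to separate the two. Also open, as far as these compounds go, is how a 3-pyridyl group or a longer chain bearing phenyl would fare at the same carbon.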